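The compounds below may be only part of what the source reports. "The series", "measured", "known", "first", "only" and "open" are said of these compounds alone.

Measured in a functional assay on OVCAR-3 cells (Homo sapiens) for antiproliferative activity, read by spectrophotometry, with a stated time of 2 days; on this read-out higher numbers stand for weaker inhibition of growth and lower numbers for stronger inhibition of growth:
Compound 1 `COc1ccc(Nc2ncc(C(F)(F)F)c(N3Cc4cccc(N(C)S(C)(=O)=O)c4C3)n2)cc1C(F)(F)F`: > 30000 nM
Compound 2 `COc1cc(Nc2ncc(C(F)(F)F)c(N3Cc4cccc(N(C)S(C)(=O)=O)c4C3)n2)c(OC)cc1Cl`: > 30000 nM
Compound 3 `CN(c1cccc2c1CN(c1nc(Nc3ccc(Nc4ccccc4)cc3)ncc1C(F)(F)F)C2)S(C)(=O)=O`: > 50000 nM

All three entries are limits of the assay and not numbers. Compound 1 and compound 2 share (the limit of > 30000 nM in this assay, at which 2 of the 3 values shown sit). Compound 3 alone holds (the limit of > 50000 nM in this assay, at which 1 of the 3 values shown sits), so it has no number from which to count.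

Compound 4 `CN(c1cccc2c1CN(c1nc(Nc3ccc(C(F)(F)F)cc3)ncc1C(F)(F)F)C2)S(C)(=O)=O` differs from compound 3 at one place: trifluoromethyl in place of anilino on an aromatic carbon. Within the data shown here, the only measured step is a step that the two limits leave unreadable from compound 1 to compound 2, so it offers no size to carry over, and it involves a different exchange. Compound 1 also carries a trifluoromethyl, and its entry is a limit, > 30000 nM. On that limit, no step beyond the scatter is expected in this assay, in either direction, and another limit is a likely outcome. The estimate amounts to an expected at least 1.2-fold lower number from compound 3 to compound 4 (0.09 log units; that floor lies within the scatter). The expected value for compound 4 is 40000 nM, within an estimated range of 12000 nM to 60000 nM.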

Compound 4, concentration for 50% growth inhibition: > 30000 nM
Compound 4: only a limit was reported; the forecaster's own chance of this, stated with the estimate: 75%; the middle value does not contradict the limit.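

In this assay compound 4 gives > 30000 nM, which is a limit and not a number. Its steps from compound 1, compound 2 and compound 3 cannot be read, as all four entries are limits. The compounds shown leave open how strongly any of them inhibits growth, and whether any of these exchanges changes that.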